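Swapping an aromatic ring for a short chain

The source may hold more compounds than are shown below. What is called first, only, known or untested is meant among the compounds shown, and "the series" means these compounds.

Compound 1 `O=C(Nc1cc(C(F)(F)F)cc(C(F)(F)F)c1)C1CCc2ccccc2N1C(=O)c1ccc(Cl)cc1` and compound 2 `O=C(Nc1cc(C(F)(F)F)cc(C(F)(F)F)c1)C1CCc2ccccc2N1C(=O)c1ccccc1Cl` share a core and differ only in where a chlorine sits on the ring attached to a carbonyl carbon. In a functional assay on ACHN cells (Homo sapiens) for cytotoxicity, read by sulforhodamine B assay, with a stated time of 72 h (on this read-out higher numbers stand for weaker inhibition of growth and lower numbers for stronger inhibition of growth), compound 1 gives 2570 nM and compound 2 gives 4700 nM; the step of a 1.8-fold higher number from compound 1 to compound 2 (0.26 log units; within the scatter) is too small to count as a change, so compound 2 merely has the higher of two nearby numbers. Compound 3 `CCCC(=O)N1c2ccccc2CCC1C(=O)Nc1cc(C(F)(F)F)cc(C(F)(F)F)c1` makes a different kind of change: propyl in place of 2-chlorophenyl on a carbonyl carbon. Among the measured compounds shown here, the one measured step concerns only the position of a chlorine on a ring that is now removed, so nothing measured speaks to this move from an aromatic ring to a three-carbon chain. With no guide, the step of a 1.3-fold higher number from compound 2 to compound 3 (0.11 log units; within the scatter) is expected to be modest, with wide uncertainty, and compound 3 is estimated at 6000 nM in this assay, within 1500 nM to 24000 nM.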

Compound 3, concentration for 50% growth inhibition: 13900 nM
For compound 3 the middle estimate is 2.3-fold (0.36 log units) below the measured one; the measured number falls inside the stated range.
By their numbers in this assay, from the lowest: compounds 1 and 2 (each within the scatter of the next); then compound 3.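

In this assay the group on the carbonyl carbon turns out to matter: a 3.0-fold higher number from compound 2 to compound 3 (0.47 log units; beyond the scatter) and a 5.4-fold higher number from compound 1 to compound 3 (0.73 log units; beyond the scatter) both lie beyond the scatter, and both point towards weaker inhibition of growth. Moving the chlorine around the ring had left compounds 1 and 2 within the scatter of each other, whereas replacing the whole chlorophenyl ring with propyl gives a change that can be read, so this position responds to a change of group even though it did not respond to a shift of the chlorine. Nothing at hand gives a reason for this step.

With a single chain, the loss of the ring cannot be told apart from the loss of the chlorine. Going by these compounds, whether a plain phenyl ring, a longer chain such as hexyl, or a chain ending in an amine would fall nearer compound 1 or compound 3 stays open.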